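Swapping iodo for thiophen-2-yl on a nucleoside core

A few compounds are considered here, and "the series" means these few. Any claim that something is new, unique, unknown or untested is made for them only; others in the source may bear on it.

Compound 2 `COc1ncnc2c1c(I)cn2[C@@H]1O[C@H](CO)[C@@H](O)[C@H]1O`: 14300 nM
Compound 1 `COc1nc(N)nc2c1c(-c1cc3ccccc3o1)cn2[C@@H]1O[C@H](CO)[C@@H](O)[C@H]1O`: > 20000 nM

Within the data shown here, in a functional assay on HeLa S3 cells (Homo sapiens) for antiproliferative activity, read by XTT assay, with a stated time of 72 h (on this read-out higher numbers stand for weaker inhibition and lower numbers for stronger inhibition), compound 2 gives 14300 nM, the only real number among the two values shown. For compound 1 the result is a limit of the assay, > 20000 nM. This is the limit of > 20000 nM in this assay, at which 1 of the 2 values shown sits. Compound 3 `COc1ncnc2c1c(-c1cccs1)cn2[C@@H]1O[C@H](CO)[C@@H](O)[C@H]1O` is not yet measured; it shows (thiophen-2-yl in place of iodo on an aromatic carbon). Compound 1 differs from compound 2 in more than one place, so it offers no single-change comparison for this swap. The step is expected to be small, a 1.0-fold higher number from compound 2 to compound 3 (0.02 log units; within the scatter), with no clear direction beyond the scatter. Compound 3 is therefore estimated at 15000 nM, between 5000 nM and 60000 nM.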

Compound 3, half-maximal inhibitory concentration: 1760 nM
For compound 3 the middle estimate is 8.5-fold (0.93 log units) above the measured one, outside the stated range (below it).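

This position is sensitive to the group it carries. On an aromatic carbon of a five-membered aromatic ring with 1 nitrogen, thiophen-2-yl in place of iodo gives, in this assay, an 8.1-fold lower number from compound 2 to compound 3 (0.91 log units; beyond the scatter), so a whole aromatic ring is accepted here and goes with stronger inhibition. The earlier compounds offered no single-change comparison at this carbon, and nothing measured here explains the gain. On these data alone, it remains open whether this gain is specific to thiophen-2-yl. A phenyl ring or a small amine on the same carbon would help to answer that.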